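The source may hold more compounds than are shown below. What is called first, only, known or untested is meant among the compounds shown, and "the series" means these compounds.

Compound 3 `Cc1ccc(CC(CNC(C)C)C(=O)N2CCN(c3ncnc4c3[C@H](C)OC4)CC2)cc1` gives 16 nM in an assay on isolated protein for inhibition of RAC-alpha serine/threonine-protein kinase (Homo sapiens); on this read-out higher numbers stand for weaker inhibition and lower numbers for stronger inhibition. Among the three compounds measured so far, its number is the second highest: compound 1 `C[C@@H]1SCc2ncnc(N3CCN(C(=O)C(Cc4ccc(Cl)cc4)C4(N)CC4)CC3)c21` gives 42 nM, a higher number, and compound 2 `CC(C)NCC(Cc1ccc(Cl)c(F)c1)C(=O)N1CCN(c2ncnc3c2[C@H](C)SC3)CC1` gives 2 nM, a lower number, and both of these gaps lie beyond the scatter of this assay.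

Compound 4 `CC(C)NCC(Cc1ccc(Cl)c(F)c1)C(=O)N1CCN(c2ncnc3c2[C@H](C)OC3)CC1` has not yet been measured. Compared with compound 3, the change is 4-chloro-3-fluorophenyl in place of 4-methylphenyl on a saturated chain carbon, two bonds along the chain from a carbonyl carbon. Among the compounds with values here, no measured pair in this set shows this exact change on its own, so its size has to be estimated rather than read off. The expectation is that the step from compound 3 to compound 4 goes towards stronger inhibition, that is a lower number, of about a 3.2-fold lower number from compound 3 to compound 4 (0.51 log units; beyond the scatter), because compound 2, which carries the 4-chloro-3-fluorophenyl group, gives 2 nM. On that basis compound 4 is expected to give 5 nM in this assay, with a likely range from 1.5 nM to 15 nM.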

Compound 4, half-maximal inhibitory concentration: 6 nM
The estimate for compound 4 lay 1.2-fold (0.08 log units) below the measured number; the measured number falls inside the stated range.
By their numbers in this assay, from the lowest: compound 2; then compound 4; then compound 3; then compound 1.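

In this assay, putting 4-chloro-3-fluorophenyl in place of 4-methylphenyl on the saturated chain carbon, with the oxygen-containing core held fixed, gives a 2.7-fold lower number from compound 3 to compound 4 (0.43 log units; beyond the scatter) and shows that this position responds to the change of aromatic group. Keeping 4-chloro-3-fluorophenyl and exchanging the sulfur of the five-membered non-aromatic ring for oxygen gives a 3.0-fold higher number from compound 2 to compound 4 (0.48 log units; beyond the scatter) and shows that the core matters too, as this step also lies beyond the scatter. No other measurement is at hand to explain either step.

From the compounds shown here alone, it remains open whether the chlorine or the fluorine accounts for the first step, which 4-chlorophenyl and 3-fluorophenyl on this chain could separate. Going by these compounds, it is also open whether exchanging sulfur for oxygen has a similar effect with 4-methylphenyl in place.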